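Hydrazone aryl exchange on compound 2, whole-animal inhibition

The source may report more compounds than this note shows. Statements on the series, on what has been measured and on what is new or still open speak of the compounds shown alone.

Compound 2 `CC1CC/C(=N\Nc2cccc(Cl)c2)c2ncc(C(=O)O)c(=O)n21` gives in a functional assay on the whole organism for inhibition, with Rattus norvegicus as the target (on this read-out lower numbers stand for an effect already at smaller amounts and higher numbers for an effect only at larger amounts of compound), only a limit of > 100 umol/kg. Compound 1 `CC1CCn2c(ncc(C(=O)O)c2=O)/C1=N/Nc1ccccc1` likewise shows only a limit, > 320 umol/kg. Compound 3 `CC1CC/C(=N\Nc2cccc(C(F)(F)F)c2)c2ncc(C(=O)O)c(=O)n21` also stands at a limit, > 1000 umol/kg. None of the three is a read number, so compound 2 cannot be ranked against the others; what is known is the limit of > 100 umol/kg in this assay, at which 1 of the 3 values shown sits, the limit of > 1000 umol/kg in this assay, at which 1 of the 3 values shown sits, and (the limit of > 320 umol/kg in this assay, at which 1 of the 3 values shown sits). Among the measured compounds shown here, the one step between measured compounds, a step that the two limits leave unreadable from compound 2 to compound 3, has no readable size. Compound 4 `CCc1ccc(N/N=C2\CCC(C)n3c2ncc(C(=O)O)c3=O)cc1` differs from compound 2 by 4-ethylphenyl in place of 3-chlorophenyl on an amine nitrogen. For the measured compounds named here, no measured step covers this change, so no direction beyond the scatter is expected. Compound 4 is therefore estimated at 300 umol/kg, between 100 umol/kg and 1000 umol/kg. The expected step that the limit leaves unreadable from compound 2 to compound 4 is an estimate only; a further limit is the likely outcome.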

Compound 4, dose for 50% inhibition: > 1000 umol/kg
Compound 4 gave a limit, no number; the forecaster's own chance of this, stated with the estimate: 70%; at least 3.3-fold (0.52 log units) between middle value and limit.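

In this assay compound 4 gives > 1000 umol/kg, a limit and not a number, so the step from compound 2 to compound 4 cannot be read. The compounds shown leave open whether any aryl exchange changes the effect.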